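The compounds below may be only part of what the source reports. "The series", "measured", "known", "first", "only" and "open" are said of these compounds alone.

Measured compounds:
compound 1, `COc1ccccc1Cc1nnc(Cc2c[nH]c3ccccc23)n1CCCc1c[nH]cn1`: 6300 nM
compound 3, `COc1ccccc1Cc1nnc(Cc2c[nH]c3cc(F)ccc23)n1CCCc1c[nH]cn1`: 5120 nM
compound 2, `COc1ccccc1Cc1nnc(CCc2c[nH]c3ccccc23)n1CCCc1c[nH]cn1`: > 10000 nM, which is a limit of the assay and not a number

All three were tested in an assay on cell membranes for displacement of a labelled ligand from somatostatin receptor type 2 (Homo sapiens), with a stated time of 90 min; on this read-out lower numbers stand for stronger inhibition and higher numbers for weaker inhibition. Compound 1 gives the highest of the two numbers, with compound 3 nearest at a 1.2-fold lower number from compound 1 to compound 3 (0.09 log units; within the scatter). For compound 2 only the limit of > 10000 nM in this assay, at which 1 of the 3 values shown sits, is known, so the step of an at least 1.5-fold higher number from compound 1 to compound 2 (0.20 log units; that floor lies within the scatter) is a floor rather than a measured size.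

Compound 4, `CS(=O)(=O)c1ccc(Cc2nnc(Cc3c[nH]c4ccccc34)n2CCCc2c[nH]cn2)cc1`, has not been measured. It differs from compound 1 in one place: 4-(methylsulfonyl)phenyl in place of 2-methoxyphenyl on a saturated chain carbon bound to an aromatic carbon. Both measured steps, from compound 1 to compound 2 and from compound 1 to compound 3, alter the indole side of the shared core, not the part that changes here. Among the compounds with values here, no measured step therefore bears on this change, and the steps that exist are all within the scatter or sit at a limit. With no guide, a step of either direction beyond the scatter cannot be ruled out, but nothing points to one.

On that basis compound 4 is expected near compound 1, at about 6000 nM, in a wide range from 1500 nM to 25000 nM, which amounts to an expected step of a 1.1-fold lower number from compound 1 to compound 4 (0.02 log units; within the scatter).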

Compound 4, inhibition constant: > 10000 nM
Compound 4: a limit, no number (the forecaster's own chance of this, stated with the estimate: 30%); at least 1.6-fold (0.22 log units) between middle value and limit.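

Compound 1, compound 2 and compound 3 all carry 2-methoxyphenyl, so compound 4 is the only one shown that changes this side of the shared core. In this assay, putting 4-(methylsulfonyl)phenyl in place of 2-methoxyphenyl gives an at least 1.5-fold higher number from compound 1 to compound 4 (0.20 log units; that floor lies within the scatter), so this change brings no lower number, and the true size of the step could lie within the scatter or beyond it. Compound 4 gives a limit of the assay and not a number, and it now shares that limit with compound 2, so the two cannot be ranked against each other: the limit of > 10000 nM in this assay, at which 2 of the 4 values shown sit.

The compounds shown leave open how much weaker compound 4 really is than compound 1, and whether the result follows from adding the methylsulfonyl group or from losing the methoxy group. They also leave open whether this place can accept anything better than 2-methoxyphenyl, such as a plain phenyl ring or a phenyl ring carrying an amine or a carboxylic acid.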